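The source may report more compounds than this note shows. Statements on the series, on what has been measured and on what is new or still open speak of the compounds shown alone.

Measured in a functional assay on PC-3 cells (Mus musculus) for cytotoxicity against PC-3 (Homo sapiens); a lower number here means a stronger inhibitor, a higher number a weaker inhibitor:
- Compound 1 `CCCN(CCC)c1c([N+](=O)[O-])cc(S(=O)(=O)Nc2ccc(C)cc2)cc1[N+](=O)[O-]`: 21000 nM
- Compound 2 `CCCN(CCC)c1c([N+](=O)[O-])cc(S(=O)(=O)Nc2cccc(OC)c2)cc1[N+](=O)[O-]`: 36000 nM
- Compound 3 `CCCN(CCC)c1c([N+](=O)[O-])cc(S(=O)(=O)Nc2ccc(Cl)c(Cl)c2)cc1[N+](=O)[O-]`: 15000 nM

Compound 3 gives 15000 nM. Going by the values given here, it stands clear of only one neighbour, with a 2.4-fold lower number from compound 2 to compound 3 (0.38 log units; beyond the scatter), while the other comparison is a 1.4-fold lower number from compound 1 to compound 3 (0.15 log units; within the scatter).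

Compound 4 `CCCN(CCC)c1c([N+](=O)[O-])cc(S(=O)(=O)Nc2cc(Cl)cc(Cl)c2)cc1[N+](=O)[O-]` carries 3,5-dichlorophenyl in place of 3,4-dichlorophenyl on a sulfonamide nitrogen. Among the compounds with values here, no measured step shows this exact swap. The closest evidence comes from exchanging the whole group at that place, which gave only a 1.7-fold higher number from compound 1 to compound 2 (0.23 log units; within the scatter), alongside the two steps above. Those exchanges stayed small, so no shift beyond the scatter is expected in this assay. The expected step is a 1.1-fold higher number from compound 3 to compound 4 (0.03 log units; within the scatter). For compound 4 the estimate is 16000 nM, with an expected range from 8000 nM to 32000 nM.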

Compound 4, half-maximal inhibitory concentration: 11000 nM
Beside the measured number, compound 4's estimate is 1.5-fold (0.16 log units) above it; the measured number falls inside the stated range.
By their numbers in this assay, from the lowest: compounds 4, 3, 1 and 2 (each within the scatter of the next, the first and the last beyond it).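

Putting 3,5-dichlorophenyl in place of 3,4-dichlorophenyl on the sulfonamide nitrogen gives a 1.4-fold lower number from compound 3 to compound 4 (0.13 log units; within the scatter) in this assay, so rearranging the two chlorines at this position changes nothing that can be told from scatter. Replacing 4-methylphenyl gives a 1.9-fold lower number from compound 1 to compound 4 (0.28 log units; within the scatter) and also stays within the scatter, whereas replacing 3-methoxyphenyl gives a 3.3-fold lower number from compound 2 to compound 4 (0.51 log units; beyond the scatter) as a modest step beyond it. Nothing available explains the size of these steps. Still open, as far as these compounds go, is how a carboxylic acid or an amine on this ring would read, or a plain alkyl chain in place of the ring.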